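A few compounds are considered here, and "the series" means these few. Any claim that something is new, unique, unknown or untested is made for them only; others in the source may bear on it.

Measured so far in an assay on isolated protein for inhibition of Retinaldehyde dehydrogenase 3 (Homo sapiens); a lower number here means a stronger inhibitor, a higher number a weaker inhibitor:
- compound 1, `CC(Sc1nc2c(cnn2C)c(=O)n1-c1ccc(CCO)cc1)c1ccccc1`, gives 3000 nM
- compound 2, `COc1cccc(C(C)Sc2nc3c(cnn3C)c(=O)n2-c2ccccc2)c1`, gives 174 nM
- compound 3, `CC(Sc1nc2c(cnn2C)c(=O)n1-c1ccc(C#N)cc1)c1ccccc1`, gives 200 nM

Compound 3 stands second among these three numbers. Its nearest neighbour is compound 2, whose value sits within the scatter of that of compound 3, so no order between the two can be claimed. Compound 1 lies well away: the step of a 15-fold lower number from compound 1 to compound 3 (1.18 log units; beyond the scatter) is large and beyond the scatter.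

The next compound, compound 4, `CC(Sc1nc2c(cnn2C)c(=O)n1-c1ccccc1)c1ccccc1`, differs from compound 3 in one place: hydrogen in place of cyano on an aromatic carbon. Going by the values given here, no measured pair shows exactly this change. Among the compounds with values here, the one measured step on the same aromatic carbon, a 15-fold lower number from compound 1 to compound 3 (1.18 log units; beyond the scatter), shows that what sits at that position can move the number a great deal, but it compares cyano with 2-hydroxyethyl, not with hydrogen. Compound 2, which carries an unsubstituted ring at the same position together with a methoxy group elsewhere, gives 174 nM, close to compound 3, yet it differs from compound 4 in a second place as well, so it is only a loose pointer.

The writer therefore expects a modest weakening for compound 4, a step of a 2.0-fold higher number from compound 3 to compound 4 (0.30 log units; within the scatter), with wide uncertainty. The estimate for compound 4 is 400 nM, with a range from 100 nM to 1500 nM.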

Compound 4, half-maximal inhibitory concentration: 73 nM
Compound 4: middle estimate off by 5.5-fold (0.74 log units), on the high side; measured number outside the range, below it.
By their numbers in this assay, from the lowest: compound 4; then compounds 2 and 3 (each within the scatter of the next); then compound 1.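

In this assay, going by these compounds alone, the step of a 2.7-fold lower number from compound 3 to compound 4 (0.44 log units; beyond the scatter) gives the first direct comparison with hydrogen on this aromatic carbon, para to a large group, and it shows that the nitrile is not needed for the number to stay low: the 4-cyanophenyl to phenyl change lowers it beyond the scatter. The step of a 41-fold lower number from compound 1 to compound 4 (1.61 log units; beyond the scatter) extends this comparison, so that the three groups measured here run in the order hydrogen, cyano and 2-hydroxyethyl, from the lowest number to the highest. The step of a 2.4-fold lower number from compound 2 to compound 4 (0.38 log units; beyond the scatter) adds that removing a methoxy group from an aromatic carbon elsewhere in the molecule also lowers the number, and no compound shown goes against the reading that hydrogen gives a lower number than each of these three groups at its own position.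

As far as these compounds go, it remains open whether a fluorine atom, a methyl group, an amine or a carboxylic acid on this carbon would give a number lower than hydrogen does. Also open, from the compounds shown here alone, is whether a shorter chain such as hydroxymethyl would sit closer to cyano or to 2-hydroxyethyl.

Nothing given here accounts for the direction or size of these steps.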